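Nitro to Carboxy Swaps in an Antiproliferative Cell Assay

This account rests on a few compounds, and the source may have more. Where it says the series, first, only, none or still open, it means among the compounds named here.

Of the compounds shown here, three sharing one core have been tested in a functional assay on G-361 cells (Homo sapiens) for antiproliferative activity; a higher number here means a weaker inhibitor, a lower number a stronger inhibitor. Compound 1 `Nc1n[nH]c(N)c1/N=N/c1cccc([N+](=O)[O-])c1` carries a nitro group on a benzene ring; compound 2 `Nc1n[nH]c(N)c1/N=N/c1ccc([N+](=O)[O-])cc1` has the same atoms joined differently, and the difference between the two cores is not broken down here. Compound 3 `Nc1n[nH]c(N)c1/N=N/c1cccc(C(=O)O)c1` arises from compound 1 through (carboxy in place of nitro on an aromatic carbon).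

In this assay compound 1 gives > 100000 nM, which is a limit of the assay rather than a number. In this assay compound 2 gives > 100000 nM, again only a limit. In this assay compound 3 gives > 100000 nM, once more a limit. Accordingly the change from compound 1 to compound 3 is a step that the two limits leave unreadable from compound 1 to compound 3, because all three results sit at the limit of > 100000 nM in this assay, at which 3 of the 3 values shown sit.

Compound 4 `Nc1n[nH]c(N)c1/N=N/c1ccc(C(=O)O)cc1` is not yet measured; it differs from compound 2 by carboxy in place of nitro on an aromatic carbon. This is the same kind of change as that from compound 1 to compound 3, but the place differs: in compound 3 the carboxy sits meta to a group of 9 heavy atoms, whereas in compound 4 it sits para to a group of 9 heavy atoms. The step from compound 2 to compound 4 is expected to be a number no higher from compound 2 to compound 4 (the limit leaves the size open), resting on compound 2 giving > 100000 nM and compound 3 giving > 100000 nM. Compound 4 is therefore estimated at 100000 nM in this assay, most likely again reported as a limit.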

Compound 4, half-maximal inhibitory concentration: > 100000 nM
Compound 4 ended at the assay's limit; the forecaster's own chance of this, stated with the estimate: 90%; the middle value lies on the limit itself.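

In this assay compound 4 gives > 100000 nM as a limit of the assay, not a number. No step can be read from compound 2 to compound 4, or between any other compounds here, because every result sits at the same limit: the limit of > 100000 nM in this assay, at which 4 of the 4 values shown sit.

The compounds shown leave open whether swapping nitro for carboxy changes activity at all, and what change to the shared core would give a readable number.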